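Hydroxyphenyl placement in two measured compounds and one candidate

This account rests on a few compounds, and the source may have more. Where it says the series, first, only, none or still open, it means among the compounds named here.

Compound 1 `Oc1cccc(-c2cc(-c3ccsc3)cc(-c3cccc(O)c3)n2)c1`: 59.2%
Compound 2 `Oc1cccc(-c2cc(-c3ccco3)cc(-c3ccccc3O)n2)c1`: 90.1%

Both numbers come from an assay on isolated protein for inhibition of DNA topoisomerase 1 (Homo sapiens), with a stated time of 30 min, tested at 100 uM; on this read-out higher numbers stand for a stronger effect at the one concentration tested and lower numbers for a weaker effect. Compound 2 gives the higher of the two, and its gap to compound 1 lies beyond the usual scatter. Among the compounds with values here, the two compounds differ in more than one place, so the numbers show only that compound 2 sits above compound 1, not which difference carries the gap.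

Compound 3 `Oc1cccc(-c2cc(-c3ccco3)cc(-c3cccc(O)c3)n2)c1` is not yet measured. It differs from compound 2 in one place: 3-hydroxyphenyl in place of 2-hydroxyphenyl on an aromatic carbon. Compound 3 thus combines the furan-2-yl group of compound 2 with the pair of 3-hydroxyphenyl groups found in compound 1. Within the data shown here, no measured pair isolates this change. The expectation is a moderate fall in this assay, a step of a number 18.1 percentage points lower from compound 2 to compound 3 (beyond the scatter) that may reach beyond the scatter. Compound 3 is estimated at 72%, within a range from 48% to 92%.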

Compound 3, a percentage reported as inhibition, at one concentration (the size of the read-out at that concentration, not a potency): 97.8%
Compound 3: the middle estimate sits 25.8 percentage points below what was measured; measured number above the stated range.
By their numbers in this assay, from the lowest: compound 1; then compounds 2 and 3 (each within the scatter of the next).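

In this assay, 3-hydroxyphenyl in place of 2-hydroxyphenyl on the aromatic carbon next to the ring nitrogen gives a number 7.7 percentage points higher from compound 2 to compound 3 (within the scatter), so this read-out does not separate the two hydroxyphenyl groups at this position when furan-2-yl is present. Within the data shown here, with the pair of 3-hydroxyphenyl groups held constant, furan-2-yl in place of thiophen-3-yl gives a number 38.6 percentage points higher from compound 1 to compound 3 (beyond the scatter), the first single-place change to lie beyond the scatter. Nothing available gives a reason for either step.

Going by these compounds, whether the hydroxyphenyl exchange stays this small with thiophen-3-yl in place of furan-2-yl remains open. Also open is how an amine or a carboxylic acid in place of the hydroxyl on the 3-hydroxyphenyl group would read, and the single-concentration read-out gives no potency for any of these compounds.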